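A Methyl-to-Chloro Swap on a Shared Core

The source may hold more compounds than are shown below. What is called first, only, known or untested is meant among the compounds shown, and "the series" means these compounds.

In a functional assay on K562 cells (Homo sapiens) for cytotoxicity, read by ELISA, with a stated time of 4 days (on this read-out higher numbers stand for weaker inhibition and lower numbers for stronger inhibition), compound 1 (`Cc1ccsc1-c1cc(-c2ccc(Cl)o2)cc(-c2ccc(Cl)cc2)n1`) gives 15600 nM. Compound 2 (`Cc1ccc(-c2cc(-c3ccc(Cl)o3)cc(-c3ccc(Cl)s3)n2)cc1`) gives 21400 nM, and these two numbers lie within the usual scatter of each other. Among the measured compounds shown here, compound 2 therefore stands level with the only other measured compound, and neither can be ranked ahead of the other.

The next compound, compound 3 (`Clc1ccc(-c2cc(-c3ccc(Cl)o3)cc(-c3ccc(Cl)s3)n2)cc1`), has chloro in place of methyl on an aromatic carbon, so a 4-methylphenyl group becomes a 4-chlorophenyl group: chloro in place of methyl on an aromatic carbon. The rest of compound 2 stays as it is.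

For the measured compounds named here, no two measured compounds differ in just one place, so the data hold no direct measure of this swap. One indirect clue is that compound 1, which also carries a 4-chlorophenyl group, gives 15600 nM. With so little to go on, no step beyond the scatter is expected in this assay. The expected change, a 1.3-fold lower number from compound 2 to compound 3 (0.10 log units; within the scatter), is small. Compound 3 is estimated at 17000 nM, with an expected range of 7000 nM to 40000 nM.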

Compound 3, half-maximal inhibitory concentration: 19300 nM
For compound 3 the middle estimate is 1.1-fold (0.06 log units) below the measured one; the range from low to high includes it.
By their numbers in this assay, from the lowest: compounds 1, 3 and 2 (each within the scatter of the next).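

Among the compounds shown here, this is the first direct measure of the swap: in this assay, putting chloro in place of methyl on an aromatic carbon gives a 1.1-fold lower number from compound 2 to compound 3 (0.04 log units; within the scatter), so turning 4-methylphenyl into 4-chlorophenyl does not separate the two compounds. A second change, at a different place, tells the same story: 5-chlorothiophen-2-yl in place of 3-methylthiophen-2-yl on an aromatic carbon gives a 1.2-fold higher number from compound 1 to compound 3 (0.09 log units; within the scatter), which also lies within the usual scatter. So neither of the two places tested has yet produced a step that can be told apart from repeat-measurement noise, and no measurement is available that could explain this flat result.

On these data alone, both swaps exchange one aromatic substituent for another of a similar kind, so it remains open whether a different sort of group in the position para to a large group, such as an amine, a carboxylic acid or a longer chain, would move the number beyond the scatter. As far as these compounds go, it also remains open whether the methyl-to-chloro swap would stay just as silent on a different core or in a different cell line.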